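The source may hold more compounds than are shown below. What is called first, only, known or untested is meant among the compounds shown, and "the series" means these compounds.

Compound 1, with the structure `FC(F)=C(F)CCSc1nccs1`, was tested in a functional assay on MCF7 cells (Homo sapiens) for cytotoxicity, read by MTT assay, with a stated time of 48 h; a higher number here means a weaker inhibitor, a lower number a stronger inhibitor. In this assay compound 1 gives > 120000 nM, which is a limit of the assay rather than a measured number. A second compound, compound 2, with the structure `FC(F)(Cl)C(F)(Cl)CCSc1nc2ccc(Cl)cc2s1`, was also tested. In this assay compound 2 gives > 120000 nM, again a limit and not a number. So compound 1 stands at the point where both known values sit, namely (the limit of > 120000 nM in this assay, at which 2 of the 2 values shown sit), and no step between measured compounds is available to show how a change in structure shifts the number.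

Compound 3, with the structure `FC(F)=C(F)CCSc1ncc(-c2ccncc2)s1`, has not yet been measured. Compared with compound 1 it carries pyridin-4-yl in place of hydrogen on an aromatic carbon. With compound 1 resting at a limit, the expected step from compound 1 to compound 3 is an at least 1.7-fold lower number from compound 1 to compound 3 (0.23 log units; that floor lies within the scatter), a move toward stronger inhibition that may or may not clear the limit. Compound 3 is therefore estimated at 70000 nM, within a range from 15000 nM to 300000 nM.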

Compound 3, half-maximal inhibitory concentration: > 120000 nM
Compound 3: no number, only a limit; the forecaster's own chance of this, stated with the estimate: 50%; middle value at least 1.7-fold (0.23 log units) from the limit.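

In this assay compound 3 gives > 120000 nM, a limit and not a number. Within the data shown here, compound 1 also rests at a limit, so no step from compound 1 to compound 3 can be read: the limit of > 120000 nM in this assay, at which 3 of the 3 values shown sit. The compounds shown leave open whether pyridin-4-yl in place of hydrogen changes the true value at all.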